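The compounds below may be only part of what the source reports. "The series", "measured", "known", "first", "only" and "open" are said of these compounds alone.

Measured so far:
compound 1 `O=C(Nc1ccc(-c2ccccc2)cc1)C1CCCN(Cc2ccc(F)c(F)c2)C1` — 2580 nM in a functional assay on A-375 cells (Homo sapiens) for antiproliferative activity; on this read-out higher numbers stand for weaker inhibition and lower numbers for stronger inhibition
compound 2 `O=C(Nc1ccc(-c2ncc[nH]2)cc1)C1CCCN(Cc2ccc(F)c(F)c2)C1` — 19000 nM in this assay

Compound 2 gives the highest of the two numbers; its nearest neighbour is compound 1, and the two are separated by a 7.4-fold higher number from compound 1 to compound 2 (0.87 log units; beyond the scatter), a modest step beyond the scatter. Compound 3 `O=C(Nc1ccc(-c2cc[nH]c2)cc1)C1CCCN(Cc2ccc(F)c(F)c2)C1` differs from compound 2 by 1H-pyrrol-3-yl in place of 1H-imidazol-2-yl on an aromatic carbon. Among the compounds with values here, the only step that bears on this change is a 7.4-fold higher number from compound 1 to compound 2 (0.87 log units; beyond the scatter), which came with the reverse kind of ring exchange; a partial return toward compound 1 is therefore expected, a step downward in this assay of about a 3.2-fold lower number from compound 2 to compound 3 (0.50 log units; beyond the scatter). Compound 3 is estimated at 6000 nM, with a range of 2000 nM to 18000 nM.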

Compound 3, half-maximal inhibitory concentration: 1420 nM
Compound 3: middle estimate off by 4.2-fold (0.63 log units), on the high side; measured number below the stated range.
By their numbers in this assay, from the lowest: compounds 3 and 1 (each within the scatter of the next); then compound 2.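

In this assay the exchange of 1H-imidazol-2-yl for 1H-pyrrol-3-yl on this aromatic carbon gives a 13-fold lower number from compound 2 to compound 3 (1.13 log units; beyond the scatter) and shows that a five-membered aromatic ring as such does not carry the loss seen with compound 2. Against phenyl, 1H-pyrrol-3-yl gives a 1.8-fold lower number from compound 1 to compound 3 (0.26 log units; within the scatter) and so cannot be told apart from it here. No measurement at hand explains the large step. Whether the second ring nitrogen of 1H-imidazol-2-yl alone accounts for the loss stays open. As far as these compounds go, how a pyridinyl ring, an aminomethyl group or a carboxylic acid would behave at this position also stays open.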